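Swapping a Saturated Ring for an Acetamidophenyl Group

This account rests on a few compounds, and the source may have more. Where it says the series, first, only, none or still open, it means among the compounds named here.

Three related compounds share a core and have been tested in a functional assay on HCC827 cells (Homo sapiens) for antiproliferative activity, read by MTT assay, with a stated time of 72 h; on this read-out lower numbers stand for stronger inhibition and higher numbers for weaker inhibition. Compound 1 `CN1CCN(c2ccc(Nc3ncc4nc(Nc5ccc(F)cc5)n([C@H]5CCCNC5)c4n3)cc2)CC1` gives 38 nM. Compound 2 `CN1CCN(c2ccc(Nc3ncc4nc(Nc5ccccc5)n([C@@H]5CCNC5)c4n3)cc2)CC1` gives 65 nM, and compound 3 `CN1CCN(c2ccc(Nc3ncc4nc(Nc5ccccc5)n([C@H]5CCN(S(=O)(=O)C6CC6)C5)c4n3)cc2)CC1` gives 1.6 nM. Among these, compound 1 stands second highest; its nearest neighbour is compound 2, within the usual scatter, while compound 3 lies far below it.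

Compound 4 `CC(=O)Nc1cccc(-n2c(Nc3ccc(F)cc3)nc3cnc(Nc4ccc(N5CCN(C)CC5)cc4)nc32)c1` differs from compound 1 in one place: 3-acetamidophenyl in place of piperidin-3-yl on an aromatic nitrogen. The saturated ring with its free amine is removed, and an aromatic ring carrying an acetamide takes its place.

Among the compounds with values here, the only step measured on this position is a 41-fold lower number from compound 2 to compound 3 (1.61 log units; beyond the scatter), where the free amine of the pyrrolidine was capped with a cyclopropylsulfonyl group. That change removed a free amine and added a group with an acceptor, and the number fell strongly. The change to compound 4 likewise removes a free amine and brings in an acetamide, though on an aromatic ring rather than a saturated one, so the comparison is only loose.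

On that basis a lower number is expected for compound 4 in this assay, with the step estimated as a 3.8-fold lower number from compound 1 to compound 4 (0.58 log units; beyond the scatter). Compound 4 is therefore estimated at 10 nM, with a range from 2 nM to 50 nM.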

Compound 4, half-maximal inhibitory concentration: 10 nM
The estimate for compound 4 equals the measured number at the digits printed; low and high end bracket the measured number.
By their numbers in this assay, from the lowest: compound 3; then compound 4; then compounds 1 and 2 (each within the scatter of the next).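

In this assay, putting 3-acetamidophenyl in place of piperidin-3-yl on the aromatic nitrogen gives a 3.8-fold lower number from compound 1 to compound 4 (0.58 log units; beyond the scatter), so among these compounds a low number at this position does not depend on a saturated ring, its ring nitrogen or its defined stereocentre. The earlier step, a 41-fold lower number from compound 2 to compound 3 (1.61 log units; beyond the scatter), kept a saturated ring and changed only the group on its nitrogen, whereas this step replaces the whole ring with a larger group built on a six-membered aromatic ring of carbon only, and the number still falls beyond the scatter. The hydrogen-bond donors and acceptors counted in the group that leaves and the group that enters are equal, and nothing measured here explains why the number falls.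

The compounds shown leave open whether the step belongs to the aromatic ring or to the acetamide: a plain phenyl group at this place would help to separate the two, as would an acetyl group on the nitrogen of the piperidin-3-yl ring. A cyclopropylsulfonyl group on that same piperidine nitrogen would also show whether the large step seen on the pyrrolidine carries over to the six-membered ring.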